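Benzofuranyl for furanyl on two purine-type cores

A few compounds are considered here, and "the series" means these few. Any claim that something is new, unique, unknown or untested is made for them only; others in the source may bear on it.

Compound 1 `O=c1[nH]cnc2c1c(-c1ccoc1)cn2[C@@H]1O[C@H](CO)[C@@H](O)[C@H]1O` and compound 3 `O=c1[nH]cnc2c1c(-c1cc3ccccc3o1)cn2[C@@H]1O[C@H](CO)[C@@H](O)[C@H]1O` share one core. In an ADME assay on MRC5 cells (Homo sapiens), read by MTT assay, with a stated time of 72 h (a lower number here means a stronger inhibitor, a higher number a weaker inhibitor), compound 1 gives only a limit of the assay, > 100000 nM. Compound 3 in this assay likewise gives only a limit, > 100000 nM. The change between them is 1-benzofuran-2-yl in place of furan-3-yl on an aromatic carbon; the step that the two limits leave unreadable from compound 1 to compound 3 cannot be read because both values sit at the limit of > 100000 nM in this assay, at which 3 of the 3 values shown sit. Compound 2 `Cc1nc(N)c2c(-c3ccoc3)cn([C@@H]3O[C@H](CO)[C@@H](O)[C@H]3O)c2n1` has a different core; the difference between the two cores is not broken down here. In this assay compound 2 gives only a limit, > 100000 nM. Compound 4 `Cc1nc(N)c2c(-c3cc4ccccc4o3)cn([C@@H]3O[C@H](CO)[C@@H](O)[C@H]3O)c2n1` carries the same change on the core of compound 2, (1-benzofuran-2-yl in place of furan-3-yl on an aromatic carbon). The step expected here is a number no higher from compound 2 to compound 4 (the limit leaves the size open), resting on the matching step that the two limits leave unreadable from compound 1 to compound 3, which showed nothing readable, and on (the limit of > 100000 nM in this assay, at which 3 of the 3 values shown sit). Compound 4 is therefore estimated at 100000 nM in this assay, most probably again as a limit rather than a number.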

Compound 4, half-maximal inhibitory concentration: 91800 nM
The estimate for compound 4 lay 1.1-fold (0.04 log units) above the measured number; measured number inside the range.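

In this assay, from the compounds shown here alone, the change to 1-benzofuran-2-yl in place of furan-3-yl on the core of compound 2 gives an at least 1.0-fold lower number from compound 2 to compound 4 (0.03 log units; that floor lies within the scatter), and the true size of this step stays open. The matching step on the core of compound 1 cannot be read, so the two cores cannot be compared and nothing shows that the change carries over with a given size. The series offers little room for such a reading: the limit of > 100000 nM in this assay, at which 3 of the 4 values shown sit.

Going by these compounds, whether the change acts alike on both cores where all members give numbers remains open. Also open, on these data alone, is how an amine, a carboxylic acid or a longer chain in place of furan-3-yl on that aromatic carbon would read in this assay.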